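The compounds below may be only part of what the source reports. "The series", "measured", "known", "first", "only" and "open" are said of these compounds alone.

Measured so far:
compound 1 `O=C(NCc1cn(Cc2ccc(C(F)(F)F)cc2)nn1)c1cn(-c2ccccc2)nc1-c1ccc(F)cc1` — 760 nM
compound 2 `COc1cc(Cn2cc(CNC(=O)c3cn(-c4ccccc4)nc3-c3ccc(F)cc3)nn2)cc(OC)c1` — 190 nM

Both were read in a functional assay on MIA PaCa-2 cells (Homo sapiens) for antiproliferative activity, read by sulforhodamine B assay, with a stated time of 48 h; a lower number here means a stronger inhibitor of growth, a higher number a weaker inhibitor of growth. For the measured compounds named here, the single step with one change, a 4.0-fold lower number from compound 1 to compound 2 (0.60 log units; beyond the scatter), moves the number beyond the scatter and leaves compound 2 with the lowest number of the two; its nearest neighbour is compound 1, a step of that same size away.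

Compound 3 `COc1cc(Cn2cc(CNC(=O)c3cn(-c4ccccc4)nc3-c3ccc(F)cc3)nn2)cc(OC)c1OC` is still to be measured. It differs from compound 2 by methoxy in place of hydrogen on an aromatic carbon, placed on an aromatic carbon of the six-membered carbon ring, ortho to two methoxy groups and para to a large group. Going by the values given here, no measured step touches this position: the one step at hand, a 4.0-fold lower number from compound 1 to compound 2 (0.60 log units; beyond the scatter), exchanges the whole aryl group on the benzylic carbon and says nothing about adding a third methoxy. In this assay compound 3 is therefore expected to stay close to compound 2, with a step of a 1.3-fold lower number from compound 2 to compound 3 (0.10 log units; within the scatter) that is not expected to exceed the scatter. The estimate for compound 3 is 150 nM, within 50 nM to 500 nM.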

Compound 3, concentration for 50% growth inhibition: 5200 nM
Beside the measured number, compound 3's estimate is 35-fold (1.54 log units) below it; measured number above the stated range.
By their numbers in this assay, from the lowest: compound 2; then compound 1; then compound 3.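

In this assay, the aromatic carbon ortho to two methoxy groups and para to a large group turns out to be highly sensitive: methoxy in place of hydrogen there gives a 27-fold higher number from compound 2 to compound 3 (1.44 log units; beyond the scatter) and so turns 3,5-dimethoxyphenyl into the weakest aryl group of the three. Set against 4-(trifluoromethyl)phenyl, the two methoxy-bearing aryl groups fall on opposite sides, with a 4.0-fold lower number from compound 1 to compound 2 (0.60 log units; beyond the scatter) for one and a 6.8-fold higher number from compound 1 to compound 3 (0.84 log units; beyond the scatter) for the other, so carrying methoxy groups does not by itself fix where a compound stands against compound 1. Nothing available gives a reason for the size of the step from the added methoxy.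

On these data alone, whether a hydroxy group, a fluorine or an ethoxy group at this same carbon would read like compound 2 or like compound 3 stays open. Also open, as far as these compounds go, is whether a single methoxy group here, without the other two methoxy groups, would give a similar rise in the number.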